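The source may hold more compounds than are shown below. What is called first, only, known or untested is meant among the compounds shown, and "the series" means these compounds.

The series shares one core, seen in compound 1 `Fc1cccc(Nc2nc(-c3cccc(F)c3)nc3ccc(F)cc23)c1` and compound 2 `Fc1cccc(-c2nc(Nc3ccccc3F)c3cc(F)ccc3n2)c1`. In a functional assay on HL-60 cells (Homo sapiens) for cytotoxicity, read by MTT assay, with a stated time of 48 h (on this read-out higher numbers stand for weaker inhibition and lower numbers for stronger inhibition), compound 1 gives 43100 nM. For compound 2 this assay reports only a limit, > 50000 nM. That is the limit of > 50000 nM in this assay, at which 1 of the 2 values shown sits. The step of an at least 1.1-fold higher number from compound 1 to compound 2 (0.06 log units; that floor lies within the scatter) therefore cannot be placed more closely than its floor, and that floor does not rise above the scatter. Compound 2 thus stands at the edge of what this assay resolves, with no number of its own.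

Compound 3 `Fc1cccc(-c2nc(Nc3cccc(Cl)c3)c3cc(F)ccc3n2)c1` differs from compound 2 in one place: 3-chlorophenyl in place of 2-fluorophenyl on a nitrogen on an aromatic ring. Going by the values given here, the only measured step that touches this nitrogen is the exchange of one fluorophenyl for another, an at least 1.1-fold higher number from compound 1 to compound 2 (0.06 log units; that floor lies within the scatter), and it stays within the scatter. Among the compounds with values here, no measured pair separates chlorine from fluorine on this ring, so nothing in the data points either way. The expectation for compound 3 in this assay is therefore no step beyond the scatter, a number no higher from compound 2 to compound 3 (the limit leaves the size open), with a real chance that this assay again returns only a limit. Compound 3 is estimated at 50000 nM, within 25000 nM to 100000 nM.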

Compound 3, half-maximal inhibitory concentration: > 50000 nM
Compound 3: a limit, no number (the forecaster's own chance of this, stated with the estimate: 55%); the middle value sits exactly at the limit.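

Chloro in place of fluoro on an aromatic carbon of the ring on this nitrogen gives an at least 1.1-fold higher number from compound 1 to compound 3 (0.06 log units; that floor lies within the scatter), so in this assay this change, like the fluorine exchange before it, shows a floor and not a measured size. The steps between the two limits cannot be read, which leaves 2-fluorophenyl and 3-chlorophenyl on this nitrogen unranked against each other. Compound 1 remains the only compound here with a number of its own, and the position has yet to yield a step that reads as beyond the scatter: the limit of > 50000 nM in this assay, at which 2 of the 3 values shown sit.

Open, from the compounds shown here alone, is whether a group on this nitrogen other than a halogen-bearing phenyl, such as a methoxyphenyl, a benzyl or a plain alkyl chain, would bring a readable number clearly under that of compound 1, 43100 nM. Also open, going by these compounds, is whether an amine or a carboxylic acid elsewhere on the shared core, away from this nitrogen, would bring the series into the range that this assay can resolve.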